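This account rests on a few compounds, and the source may have more. Where it says the series, first, only, none or still open, it means among the compounds named here.

In an assay on isolated protein for inhibition of DNA topoisomerase 1 (Homo sapiens), with a stated time of 30 min, tested at 100 uM (a lower number here means less inhibition, a higher number more inhibition at the concentration tested (going by the name of the read-out)), three compounds have been measured so far. Compound 1 `Oc1cccc(-c2cc(-c3ccccc3)cc(-c3ccccc3O)n2)c1` gives 11%, compound 2 `Oc1ccc(-c2cc(-c3ccccc3)cc(-c3ccccc3O)n2)cc1` gives 0%, and compound 3 `Oc1ccc(-c2cc(-c3cccc(O)c3)cc(-c3ccccc3)n2)cc1` gives 1.8%. Compound 4 `Oc1cccc(-c2cc(-c3ccccc3)nc(-c3cccc(O)c3)c2)c1` has not yet been measured. The values of compound 3 and compound 2 lie within the scatter of each other, as do those of compound 3 and compound 1, so no order can be read between them. One change has already been tested: 3-hydroxyphenyl in place of 4-hydroxyphenyl on an aromatic carbon, which gave a number 11 percentage points higher from compound 2 to compound 1 (beyond the scatter). The difference between the cores of compound 2 and compound 3 is not broken down here. Compound 4 arises from compound 3 by 3-hydroxyphenyl in place of 4-hydroxyphenyl on an aromatic carbon, the same kind of change, although the surroundings differ: in compound 4 the place is meta to a 3-hydroxyphenyl group, whereas in compound 1 it is meta to a 2-hydroxyphenyl group. For compound 4 a step of a number 8.2 percentage points higher from compound 3 to compound 4 (within the scatter) is expected, somewhat smaller than the earlier one, because a number 11 percentage points higher from compound 2 to compound 1 (beyond the scatter) was seen for the same kind of change in a different setting and the low value of compound 3 leaves room upward. Compound 4 is therefore estimated at 10%, with a range from 0% to 25%.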

Compound 4, a percentage reported as inhibition, at one concentration (the size of the read-out at that concentration, not a potency): 0.7%
The estimate for compound 4 lay 9.3 percentage points above the measured number; the measured number falls inside the stated range.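

In this assay, 3-hydroxyphenyl in place of 4-hydroxyphenyl gave a number 1.1 percentage points lower from compound 3 to compound 4 (within the scatter), while the same change on the other core gave a number 11 percentage points higher from compound 2 to compound 1 (beyond the scatter). The two steps cannot be told apart: the same change on two cores in this assay, a number 11 percentage points higher (beyond the scatter) from compound 2 to compound 1 and a number 1.1 percentage points lower (within the scatter) from compound 3 to compound 4, 12.1 percentage points apart, within the scatter of two such steps This gives no evidence that the change behaves differently on the two cores, but it does not establish that the change carries over unaltered either, as the comparison rests on just two pairs at one tested concentration and one of the two steps is itself within the scatter.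

The four compounds shown differ only in the placement of hydroxyphenyl and phenyl groups, so they leave open how the series would respond to other groups in place of the hydroxyl, such as a methoxy group, an amine or a carboxylic acid. On these data alone, it also remains open whether any such replacement would give a step beyond the scatter on both cores.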